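Thiourea Series: A Furanylmethyl Group Replaces an Iodophenyl Ring

The source may hold more compounds than are shown below. What is called first, only, known or untested is meant among the compounds shown, and "the series" means these compounds.

Compound 1, `FC(F)(F)c1cccc(NC(=S)Nc2ccc(I)cc2)c1`: 9500 nM
Compound 2, `CCCCc1ccc(NC(=S)Nc2cccc(C(F)(F)F)c2)c(C)c1`: 18000 nM
Compound 3, `CCOC(=O)c1ccc(NC(=S)Nc2cccc(C(F)(F)F)c2)cc1`: 71000 nM

These three compounds share a thiourea core bearing a trifluoromethylphenyl group, and each was tested in an ADME assay on Vero 76 cells (Chlorocebus sabaeus) for cytotoxicity, read by crystal violet staining, with a stated time of 96 h; on this read-out lower numbers stand for higher toxicity in this test and higher numbers for lower toxicity in this test. Compound 1 stands at the lowest of the three numbers, meaning it is the most toxic in this test among them. Compound 2 lies within the usual scatter of compound 1, so no order between those two can be claimed. Among the measured compounds shown here, the only step that clearly stands apart is a 7.5-fold higher number from compound 1 to compound 3 (0.87 log units; beyond the scatter), a modest move toward lower toxicity.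

Compound 4, `FC(F)(F)c1cccc(NC(=S)NCc2ccco2)c1`, has not yet been measured in this assay. It differs from compound 1 in one place: (furan-2-yl)methyl in place of 4-iodophenyl on an amide-type nitrogen. For the measured compounds named here, no measured step mirrors this change, since the measured step alters a substituent on the ring rather than replacing the ring itself. That step, a 7.5-fold higher number from compound 1 to compound 3 (0.87 log units; beyond the scatter), does show that changing this end of the core can shift the number well beyond the scatter, and in the direction of lower toxicity. On that basis a rise of similar size is expected, though with wide uncertainty. Compound 4 is therefore estimated at 40000 nM, with a likely range from 12000 nM to 130000 nM, which corresponds to an expected step of a 4.2-fold higher number from compound 1 to compound 4 (0.62 log units; beyond the scatter).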

Compound 4, half-maximal cytotoxic concentration: 50000 nM
Estimate against measurement, compound 4: 1.3-fold (0.10 log units) below; low and high end bracket the measured number.
By their numbers in this assay, from the lowest: compounds 1 and 2 (each within the scatter of the next); then compounds 4 and 3 (each within the scatter of the next).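

In this assay, putting (furan-2-yl)methyl in place of 4-iodophenyl on the amide-type nitrogen gives a 5.3-fold higher number from compound 1 to compound 4 (0.72 log units; beyond the scatter) and so a modest move toward lower toxicity in this test. The earlier step, a 7.5-fold higher number from compound 1 to compound 3 (0.87 log units; beyond the scatter), exchanged only a substituent and kept the six-membered aromatic ring of carbon in place, whereas this change removes that ring and the iodine altogether. The new result therefore shows that this end of the molecule tolerates a replacement of the whole group, a five-membered aromatic ring with one hetero atom taking over, and that the number moves in the same direction as it did with the smaller edit, though nothing measured here explains why the number rises.

Going by these compounds, because the ring, the iodine and the link to the nitrogen all change in one step, the share of each in the rise remains open. A plain benzyl group on the same nitrogen would help to separate the effect of the furan ring from that of the added carbon, and a simple butyl chain there would test whether any aromatic ring is needed at all.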